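A few compounds are considered here, and "the series" means these few. Any claim that something is new, unique, unknown or untested is made for them only; others in the source may bear on it.

Measured in a physicochemical assay for solubility, read by nephelometry, in phosphate buffer, measured as kinetic solubility, with a stated time of 30 min, at pH 6.5; a higher number here means a more soluble compound, a lower number a less soluble compound:
- compound 1 `O=C(O)c1cc([C@H]2CC[C@]3(CC2)OOC2(O3)C3CC4CC(C3)CC2C4)ccc1O`: < 1.6 ug/mL
- compound 2 `O=C(O)COc1ccc([C@H]2CC[C@]3(CC2)OOC2(O3)C3CC4CC(C3)CC2C4)cc1`: < 1.6 ug/mL

Compound 2 stands at < 1.6 ug/mL, which is a limit of the assay and not a number. The same holds for compound 1, so no numerical value is available in the pair: the limit of < 1.6 ug/mL in this assay, at which 2 of the 2 values shown sit.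

Compound 3 `O=C(O)COc1ccc([C@H]2CC[C@]3(CC2)OOC2(O3)C3CC4CC(C3)CC2C4)cc1C(=O)O` differs from compound 2 by carboxy in place of hydrogen on an aromatic carbon, with the carboxy ortho to a carboxymethoxy group. For the measured compounds named here, no measured step covers this change. A modest rise in this assay is expected, estimated as an at least 3.7-fold higher number from compound 2 to compound 3 (0.57 log units; beyond the scatter), though a reading at the limit remains possible. For compound 3 the estimate is 6 ug/mL, with an expected range of 1.6 ug/mL to 50 ug/mL.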

Compound 3, solubility: < 3.1 ug/mL
Compound 3 gave a limit, no number (the forecaster's own chance of this, stated with the estimate: 40%); middle value at least 1.9-fold (0.28 log units) from the limit.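

In this assay, for the compounds shown here, compound 1, compound 2 and compound 3 all read as limits, not numbers, so no step among them can be read. The compounds shown leave open what size the carboxy and carboxymethyl changes have in this assay.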